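The compounds below may be only part of what the source reports. "The series", "measured", "known", "first", "only" and "open" are said of these compounds alone.

Measured in an assay on cells for displacement of a labelled ligand from adenosine receptor A1 (Homo sapiens), with a stated time of 60 min, tested at 1 uM (a lower number here means less inhibition, a higher number more inhibition at the concentration tested (going by the name of the read-out)), so far:
compound 1, `CC1=C(C(=O)OC(C)C)[C@H](c2ccco2)N/C(=N/C#N)N1`, gives 18%
compound 2, `CCOC(=O)C1=C(C)N/C(=N\C#N)NC1C1CCCC1`, gives 11%
compound 3, `CCOC(=O)C1=C(C)NC(=O)NC1C1CCCC1`, gives 3%

Compound 1 holds the highest of the three numbers in this assay. Its nearest neighbour is compound 2, whose number is lower but within the usual scatter, so no order between compound 1 and compound 2 can be read from these two values. Compound 3 is the furthest from compound 1, and that gap lies beyond the scatter. Within the data shown here, no two of the measured compounds differ in a single place, so no step between measured compounds is available to calibrate the series.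

The next compound, compound 4, is `CC1=C(C(=O)OC(C)C)C(c2ccco2)N/C(=N/C#N)N1` and remains to be measured in this assay. Relative to compound 1 the change is: the two compounds have the same atoms and bonds; at least one stereo element is drawn with a configuration in one of them and without one in the other: 1 of 2 stereo elements differ; a stereocentre at a saturated ring carbon is drawn R in compound 1 and without a configuration in compound 4. Atoms and bonds are the same; only the drawing of the stereocentre at the saturated ring carbon differs.

With no step of this kind in the series, the expectation for the step from compound 1 to compound 4 is none beyond the scatter, leaning if at all slightly lower; the expected step is a number 4 percentage points lower from compound 1 to compound 4 (within the scatter). For compound 4 in this assay the estimate is 14%, within an expected range of 4% to 24%.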

Compound 4, a percentage reported as inhibition, at one concentration (the size of the read-out at that concentration, not a potency): 21%
Estimate against measurement, compound 4: 7 percentage points below, within the range that was stated.
By their numbers in this assay, from the lowest: compounds 3, 2, 1 and 4 (each within the scatter of the next, the first and the last beyond it).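

In this assay, among these compounds, the series now has its only readable step, a number 3 percentage points higher from compound 1 to compound 4 (within the scatter). The atoms and bonds stay the same, so this step measures what the drawing of the saturated ring carbon alone is worth in this read-out, and drawn R against no configuration gives no separation beyond the usual scatter. The pair therefore offers no sign that the configuration drawn at this carbon matters at the single concentration tested, and that reading rests on one thing only, which is all that separates the two compounds: the fact that one of compounds 1 and 4 is drawn with a defined configuration and the other without, at the place where they differ

On these data alone, whether a compound drawn with the opposite configuration at this carbon would match compound 1 remains open, and the drawing of compound 4 does not tell what its sample holds at that centre. Also open is how the number responds when the group on this carbon gives way to an amine or a longer chain, or when a carboxylic acid takes the place of the ester, since a read-out at one concentration gives no potency for any of these compounds.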